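Swapping Nitrile for Nitro on a Chlorinated Biphenyl Glucoside

The compounds below may be only part of what the source reports. "The series", "measured", "known", "first", "only" and "open" are said of these compounds alone.

Three glucosides share one core. Compound 1 `OC[C@H]1O[C@H](Oc2ccc(-c3ccc(Cl)cc3Cl)cc2Cl)[C@@H](O)[C@@H](O)[C@@H]1O` has no result in a physicochemical assay for lipophilicity, read by LC-MS, measured as octanol-water partition, with a stated time of 2 h, at pH 7.4, tested at 1 uM; on this read-out higher numbers stand for higher lipophilicity and lower numbers for lower lipophilicity: "not determined" (no result reported). Compound 2 `Cc1ccc(-c2ccc(O[C@H]3O[C@H](CO)[C@@H](O)[C@H](O)[C@@H]3O)c(Cl)c2)cc1` gives 3.3 in this assay, and compound 3 `N#Cc1cccc(-c2ccc(O[C@H]3O[C@H](CO)[C@@H](O)[C@H](O)[C@@H]3O)c(Cl)c2)c1` gives 2.1; the step of a number 1.20 log units lower from compound 2 to compound 3 (beyond the scatter) places compound 3 as the lower of the two measured numbers. Compound 4 `O=[N+]([O-])c1cccc(-c2ccc(O[C@H]3O[C@H](CO)[C@@H](O)[C@H](O)[C@@H]3O)c(Cl)c2)c1` has not yet been measured. It differs from compound 3 by nitro in place of cyano on an aromatic carbon. Going by the values given here, no measured step exchanges nitro for cyano; the only step available, a number 1.20 log units lower from compound 2 to compound 3 (beyond the scatter), concerns a different exchange and shows merely how far one change on this ring can move the number. For compound 4 a small upward step a number 0.30 log units higher from compound 3 to compound 4 (within the scatter) is expected. The estimate for compound 4 is 2.4, within 2 to 2.8.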

Compound 4, distribution coefficient: 2.4
Compound 4: the middle estimate sits on the measured number at the digits printed, within the range that was stated.
By their numbers in this assay, from the lowest: compounds 3 and 4 (each within the scatter of the next); then compound 2.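

In this assay, the exchange of cyano for nitro on this aromatic carbon gives a number 0.30 log units higher from compound 3 to compound 4 (within the scatter), so the two groups cannot be told apart on this read-out. Compound 4 remains separated from the 4-methylphenyl compound, with a number 0.90 log units lower from compound 2 to compound 4 (beyond the scatter), as compound 3 was. The compounds offer no measured reason for either step. Open, going by these compounds, is how an amine or a carboxylic acid on this same carbon would read, and whether the closeness of cyano and nitro would hold with either group elsewhere on the ring.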